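A few compounds are considered here, and "the series" means these few. Any claim that something is new, unique, unknown or untested is made for them only; others in the source may bear on it.

Compound 3 `COc1cc(NC(C)CCCNC(=O)NNC(=O)Nc2cccc(Cl)c2)c2ncccc2c1` gives 93000 nM in a functional assay on MOLT-4 cells (Homo sapiens) for inhibition, read by MTT assay, with a stated time of 72 h (a lower number here means a stronger inhibitor, a higher number a weaker inhibitor), the highest of the two numbers shown. Its nearest neighbour is compound 2 `COc1cc(NC(C)CCCNC(=O)Nc2ccc(F)cc2)c2ncccc2c1`, which gives 24000 nM; the two are separated by a 3.9-fold higher number from compound 2 to compound 3 (0.59 log units; beyond the scatter). Compound 1 `COc1cc(NC(C)CCCNC(=O)NNC(=O)Nc2cccc(F)c2)c2ncccc2c1` reaches only a limit of the assay, >= 250000 nM. Compound 4 `COc1cc(NC(C)CCCNC(=O)NNC(=O)Nc2ccc(F)cc2)c2ncccc2c1` differs from compound 3 by 4-fluorophenyl in place of 3-chlorophenyl on an amide-type nitrogen. Among the measured compounds shown here, one measured step bears on this change: an at least 2.6-fold lower number from compound 1 to compound 3 (0.42 log units; beyond the scatter), where the chloro compound gave the lower number, while compound 1 with fluoro sits at the limit of >= 250000 nM in this assay, at which 1 of the 3 values shown sits. Returning from chloro to fluoro on the same amide-type nitrogen is therefore expected to give a 1.9-fold higher number from compound 3 to compound 4 (0.29 log units; within the scatter), with a real chance that only a limit is reported. Compound 4 is estimated at 180000 nM, within a range from 60000 nM to 400000 nM.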

Compound 4, half-maximal inhibitory concentration: >= 250000 nM
Compound 4 ended at the assay's limit; the forecaster's own chance of this, stated with the estimate: 45%; at least 1.3-fold (0.14 log units) between middle value and limit.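

Among the compounds shown here, with the 4-fluorophenyl group present on both sides, ((4-fluorophenyl)carbamoyl)amino in place of 4-fluorophenyl on the amide-type nitrogen gives an at least 10-fold higher number from compound 2 to compound 4 (1.01 log units; beyond the scatter) in this assay. 4-Fluorophenyl in place of 3-chlorophenyl gives an at least 2.6-fold higher number from compound 3 to compound 4 (0.42 log units; beyond the scatter), leaving compound 3 as the only one of compounds 1, 3 and 4 with a number rather than a limit. The value of compound 4 is a limit: the limit of >= 250000 nM in this assay, at which 2 of the 4 values shown sit.

The step between compound 1 and compound 4 cannot be read, as both values are limits. The compounds shown leave open whether the halogen or its place on the ring matters more, which 4-chlorophenyl could separate.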